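Methoxy for bromo on the oxazole of the ketone series

The compounds below may be only part of what the source reports. "The series", "measured", "known", "first", "only" and "open" are said of these compounds alone.

Compound 1 `CN(C)C(=O)c1coc(C(=O)CCCCCCc2ccccc2)n1` gives 3390 nM in an assay on HEK-293T cells for inhibition of diacylglycerol lipase-alpha (Homo sapiens), read by colorimetric assay; on this read-out higher numbers stand for weaker inhibition and lower numbers for stronger inhibition. Compound 2 `O=C(CCCCCCc1ccccc1)c1nc(Br)co1` shows only a limit of the assay, > 10000 nM, in this assay. Compound 3 `CNC(=O)c1coc(C(=O)CCCCCCc2ccccc2)n1` likewise reaches only the limit > 10000 nM in this assay. Going by the values given here, the step of an at least 2.9-fold higher number from compound 1 to compound 2 (0.46 log units; beyond the scatter) is the one readable change to compound 2; the step that the two limits leave unreadable from compound 2 to compound 3 is not readable. Two of the three values sit at the limit of > 10000 nM in this assay, at which 2 of the 3 values shown sit, so compound 2 stands at the weak end of the numbers shown.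

Compound 4 `COc1cnc(C(=O)CCCCCCc2ccccc2)o1` differs from compound 2 in this way: a group of 7 heavy atoms (4 carbon, 1 nitrogen, 2 oxygen; one five-membered aromatic ring with 2 hetero atoms) in place of a group of 6 heavy atoms (3 carbon, 1 nitrogen, 1 oxygen, 1 bromine; one five-membered aromatic ring with 2 hetero atoms), on a carbonyl carbon. Among the compounds with values here, no measured step exchanges bromo for methoxy on the shared core, so no direction can be drawn from the data. Compound 4 is expected to stay weak, with the step of an at least 1.1-fold lower number from compound 2 to compound 4 (0.04 log units; that floor lies within the scatter) only an estimate. Compound 4 is estimated at 9000 nM, within 2500 nM to 30000 nM.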

Compound 4, half-maximal inhibitory concentration: > 10000 nM
Compound 4 was reported as a limit; the forecaster's own chance of this, stated with the estimate: 55%; middle value at least 1.1-fold (0.04 log units) away from the limit.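

In this assay compound 4 gives > 10000 nM, a limit of the assay. Going by these compounds alone, compound 2 also stands at a limit, and no step between compound 2 and compound 4 can be read. Going by these compounds, whether methoxy and bromo differ in strength of inhibition on the shared core stays open.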